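Cyclopentyl in place of piperidin-3-yl on the shared core

The compounds below may be only part of what the source reports. "The series", "measured", "known", "first", "only" and "open" are said of these compounds alone.

Values in a functional assay on HCT-116 cells (Homo sapiens) for cytotoxicity, with a stated time of 48 h; on this read-out lower numbers stand for stronger inhibition of growth and higher numbers for weaker inhibition of growth:
- Compound 1 `Nc1nc(-c2cc(N3C[C@H](O)[C@@H](O)C3)ccc2O)cc(C2CCCCC2)n1`: 800 nM
- Compound 2 `Nc1nc(NC2CCCCC2)cc(-c2cc(N3C[C@H](O)[C@@H](O)C3)ccc2O)n1`: 900 nM
- Compound 3 `Nc1nc(-c2cc(N3C[C@H](O)[C@@H](O)C3)ccc2O)cc(C2CCCNC2)n1`: > 10000 nM

Compound 3 gives only a limit of the assay, > 10000 nM, and no number. Compound 4 `Nc1nc(-c2cc(N3C[C@H](O)[C@@H](O)C3)ccc2O)cc(C2CCCC2)n1` carries cyclopentyl in place of piperidin-3-yl on an aromatic carbon. Two large measured steps bear on this change. Putting piperidin-3-yl in place of cyclohexyl gave an at least 12-fold higher number from compound 1 to compound 3 (1.09 log units; beyond the scatter), and putting it in place of cyclohexylamino gave an at least 11-fold higher number from compound 2 to compound 3 (1.04 log units; beyond the scatter). Exchanging cyclohexyl for cyclohexylamino gave a 1.1-fold higher number from compound 1 to compound 2 (0.05 log units; within the scatter). Cyclopentyl, like the cyclohexyl of compound 1, is a ring of carbon only, so a large step to a lower number is expected in this assay. The expected change is an at least 8.3-fold lower number from compound 3 to compound 4 (0.92 log units; beyond the scatter). Compound 4 is estimated at 1200 nM, with an expected range from 500 nM to 4000 nM.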

Compound 4, concentration for 50% growth inhibition: 400 nM
For compound 4 the middle estimate is 3.0-fold (0.48 log units) above the measured one; the whole stated range lies above it.
By their numbers in this assay, from the lowest: compounds 4, 1 and 2 (each within the scatter of the next, the first and the last beyond it). At a limit, above all of these: compound 3.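

In this assay, a second ring of carbon only at this position again stands clear of the piperidin-3-yl of compound 3, with an at least 25-fold lower number from compound 3 to compound 4 (1.39 log units; beyond the scatter), a step read against a limit: the limit of > 10000 nM in this assay, at which 1 of the 4 values shown sits.

The ring need not be six-membered: cyclopentyl gives a 2.0-fold lower number from compound 1 to compound 4 (0.30 log units; within the scatter), and a 2.3-fold lower number from compound 2 to compound 4 (0.35 log units; beyond the scatter), a modest step.

The compounds shown leave open how this position responds to an open-chain group such as isopropyl or to a cyclopropyl ring. They also leave open whether a piperidin-3-yl with its nitrogen carrying an acetyl group would stay at the limit.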